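Hydroxymethyl for Propoxycarbonyl in Compound 4

This account rests on a few compounds, and the source may have more. Where it says the series, first, only, none or still open, it means among the compounds named here.

In a functional assay on SK-BR-3 cells (Homo sapiens) for cytotoxicity, read by MTT assay, with a stated time of 72 h (a lower number here means that less compound is needed, a higher number that more compound is needed for the effect), compound 1 `CCc1cccc2c(O)c(-c3occ(C)c3C(=O)O)ccc12` gives 1 ug/mL. Compound 2 `CCOc1c(-c2occ(C)c2C(=O)O)ccc2c(CC)cccc12` gives > 10 ug/mL, which is a limit of the assay and not a number. Compound 3 `CCCOC(=O)c1c(C)coc1-c1ccc2c(CC)cccc2c1OC` gives > 10 ug/mL, again only a limit. Compound 3 thus shares with compound 2 (the limit of > 10 ug/mL in this assay, at which 2 of the 3 values shown sit), and it offers no exact starting point.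

Compound 4 `CCc1cccc2c(OC)c(-c3occ(C)c3CO)ccc12` differs from compound 3 at a single place: hydroxymethyl in place of propoxycarbonyl on an aromatic carbon. Hydroxymethyl takes the place of propoxycarbonyl on an aromatic carbon, so the change lies away from the oxygen involved in the only measured step. That step, an at least 10-fold higher number from compound 1 to compound 2 (1.00 log units; beyond the scatter), lies beyond the scatter and comes with ethyl in place of hydrogen on an oxygen on an aromatic ring. Among the compounds with values here, no measured step covers the exchange at the aromatic carbon itself, so it bears on this case only indirectly. Compound 4, like compound 3, has no hydrogen on that oxygen, and a large gain is therefore not expected. The expected step is a number no higher from compound 3 to compound 4 (the limit leaves the size open), with no change beyond the scatter foreseen. For compound 4 the estimated value is 10 ug/mL, with an expected range of 3 ug/mL to 30 ug/mL.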

Compound 4, concentration for half-maximal effect: 0.73 ug/mL
Compound 4: the middle estimate sits 14-fold (1.14 log units) above what was measured; measured number below the stated range.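

In this assay, the aromatic carbon of the five-membered ring proves to be a position where a single exchange matters: hydroxymethyl in place of propoxycarbonyl gives an at least 13-fold lower number from compound 3 to compound 4 (1.13 log units; beyond the scatter). Compound 3 gives > 10 ug/mL, which is only a limit of the assay, so the step has a lower bound but no exact size, and this compound is not alone in sitting there: the limit of > 10 ug/mL in this assay, at which 2 of the 4 values shown sit. The earlier compounds shown here showed a change only at the oxygen on the aromatic ring, whereas compound 4 gives 0.73 ug/mL with no hydrogen on that oxygen, so a measured value in this assay does not require that hydrogen.

The compounds shown do not separate the loss of propoxycarbonyl from the arrival of hydroxymethyl, so it remains open whether a smaller ester such as methoxycarbonyl, or a plain methyl, would behave like either group at this carbon. From the compounds shown here alone, it is also open whether an aminomethyl group or a longer chain such as hydroxyethyl would keep the value seen for compound 4 at this position.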